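The source may hold more compounds than are shown below. What is called first, only, known or untested is meant among the compounds shown, and "the series" means these compounds.

The series shares one core, seen in compound 1 `CC(C)(C)Cc1csc(N)c1C(=O)c1ccc(Cl)cc1`, which in an assay on CHO cells for displacement of a labelled ligand from adenosine receptor A1 (Homo sapiens), read by scintillation counting, tested at 10 uM (on this read-out higher numbers stand for more inhibition at the one concentration tested (going by the name of the read-out) and lower numbers for less inhibition), gives 1%. Compound 2 `Cc1ccccc1-c1sc(N)c(C(=O)c2ccc(Cl)cc2)c1CC(C)(C)C` carries a 2-methylphenyl in place of hydrogen on an aromatic carbon, and in this assay compound 2 gives 1%; the step of no change at the digits printed from compound 1 to compound 2 (within the scatter) lies within the scatter. Compound 3 `Cc1ccc(C(=O)c2c(CC(C)(C)C)csc2N)cc1` carries methyl in place of chloro on an aromatic carbon, and in this assay compound 3 gives 1%; the step of no change at the digits printed from compound 1 to compound 3 (within the scatter) also lies within the scatter. Compound 3 thus stands level with compounds 1 and 2 at the digits shown, all three at the bottom of the read-out.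

Compound 4 `Cc1ccc(C(=O)c2c(N)sc(Br)c2CC(C)(C)C)cc1` differs from compound 3 by bromo in place of hydrogen on an aromatic carbon. Within the data shown here, no measured step touches this position, and the two steps that were measured, from compound 1 to compound 2 and from compound 1 to compound 3, both left this assay unchanged within the scatter. The expected step of a number 2 percentage points higher from compound 3 to compound 4 (within the scatter) is therefore one of no change beyond the scatter. For compound 4 the estimate in this assay is 3%, with a range from -8% to 15%.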

Compound 4, a percentage reported as inhibition, at one concentration (the size of the read-out at that concentration, not a potency): 1%
Compound 4: the middle estimate sits 2 percentage points above what was measured, and the stated range covers the measured number.
By their numbers in this assay, from the lowest: compounds 1, 2, 3 and 4 (each within the scatter of the next).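

In this assay, bromo in place of hydrogen on the aromatic carbon next to the ring sulfur leaves the reading where it was, with no change at the digits printed from compound 3 to compound 4 (within the scatter). A single bromine at this position, next to the ring atom that bears a neopentyl group, therefore does not lift compound 4 off the bottom of the read-out, where compounds 1, 2 and 3 also lie, so the result cannot show how bromo would act on a compound with measurable inhibition. Nothing available explains this result.

From the compounds shown here alone, it remains open whether an amine or a carboxylic acid on this same carbon would move the reading. Also open, going by these compounds, is whether a longer chain in place of the neopentyl group, or an amide in place of the amino group, would give any measurable inhibition.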